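The compounds below may be only part of what the source reports. "The series", "measured", "known", "first", "only" and "open" are said of these compounds alone.

Measured in an ADME assay (liver) for metabolic stability, with Liver microsome (Homo sapiens) as the target, using microsomes and NADPH, with a stated time of 30 min, tested at 1 uM; on this read-out lower numbers stand for slow clearance and higher numbers for fast clearance:
Compound 1 `CC(C)(O)C#Cc1cc(C(O)(C(F)(F)F)C(F)(F)F)cnc1N1CCN(S(=O)(=O)c2ccc(N)nc2)CC1` gives < 14 mL.min-1.g-1, which is a limit of the assay and not a number.
Compound 2 `CC(C)n1cc(-c2cc(C(O)(C(F)(F)F)C(F)(F)F)cnc2N2CCN(S(=O)(=O)c3ccc(N)nc3)CC2)cn1` gives 38 mL.min-1.g-1.
Compound 3 `Nc1ccc(S(=O)(=O)N2CCN(c3ncc(C(O)(C(F)(F)F)C(F)(F)F)cc3-c3ccoc3)CC2)cn1` gives < 14 mL.min-1.g-1, again a limit of the assay.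

Compound 3 thus sits at the lowest edge of what this assay reports, sharing that position with compound 1 (the limit of < 14 mL.min-1.g-1 in this assay, at which 2 of the 3 values shown sit). The step that the two limits leave unreadable from compound 1 to compound 3 cannot be sized, whereas the step of an at least 2.7-fold lower number from compound 2 to compound 3 (0.43 log units; beyond the scatter) is readable and at least modest.

Compound 4 `Nc1ccc(S(=O)(=O)N2CCN(c3ncc(C(O)(C(F)(F)F)C(F)(F)F)cc3-c3cnccc3F)CC2)cn1` differs from compound 3 in one place: 4-fluoropyridin-3-yl in place of furan-3-yl on an aromatic carbon. Among the measured compounds shown here, two measured steps bear on this position. The step of an at least 2.7-fold higher number from compound 1 to compound 2 (0.43 log units; beyond the scatter) shows that a heteroaromatic ring here can yield a number above the limit; the step of an at least 2.7-fold lower number from compound 2 to compound 3 (0.43 log units; beyond the scatter) shows another heteroaromatic ring returning to the limit. Which of the two the 4-fluoropyridin-3-yl ring resembles cannot be settled from three compounds, so a step of an at least 1.2-fold higher number from compound 3 to compound 4 (0.10 log units; that floor lies within the scatter) is expected, small and upward, with a real chance that compound 4 again reports only the limit. The estimate for compound 4 is 18 mL.min-1.g-1, ranging from 9 mL.min-1.g-1 to 36 mL.min-1.g-1.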

Compound 4, intrinsic clearance in microsomes: 17 mL.min-1.g-1
For compound 4 the middle estimate is 1.1-fold (0.02 log units) above the measured one; low and high end bracket the measured number.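

In this assay, among the compounds shown here, compound 4 is the first compound here with a six-membered aromatic ring at this position, and it gives a number rather than a limit. The step of a 2.2-fold lower number from compound 2 to compound 4 (0.35 log units; beyond the scatter) shows that 4-fluoropyridin-3-yl in place of 1-isopropyl-1H-pyrazol-4-yl lowers the number while it stays readable. The steps of an at least 1.2-fold higher number from compound 3 to compound 4 (0.08 log units; that floor lies within the scatter) and an at least 1.2-fold higher number from compound 1 to compound 4 (0.08 log units; that floor lies within the scatter) are floors only, and as both floors lie within the scatter, neither shows a real rise over the compounds that report a limit: the limit of < 14 mL.min-1.g-1 in this assay, at which 2 of the 4 values shown sit.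

A plain pyridin-3-yl or phenyl ring at this position would separate the part played by the fluorine from that of the ring nitrogen, and the compounds shown leave this open. How an amine or a carboxylic acid on this aromatic carbon would read in this assay is open too.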